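Extending a Short Alkyl Chain on Two Antagonist Cores

The source may report more compounds than this note shows. Statements on the series, on what has been measured and on what is new or still open speak of the compounds shown alone.

Compound 1 `Cc1ccccc1-c1ccc2[nH]ncc2c1` and compound 2 `CCc1ccccc1-c1ccc2[nH]ncc2c1` share one core and differ in a single spot: methyl in place of hydrogen on a saturated chain carbon bound to an aromatic carbon. In an assay on CHO-TREX cells for antagonist activity at transient receptor potential cation channel subfamily A member 1 (Homo sapiens), read by FLIPR and calcium flux, with a stated time of 10 min (a lower number here means a stronger inhibitor, a higher number a weaker inhibitor), compound 1 gives 7810 nM, while compound 2 gives 584 nM, a step of a 13-fold lower number from compound 1 to compound 2 (1.13 log units; beyond the scatter). Compound 3 `CCc1cc2[nH]ncc2cc1-c1ccccc1C(F)(F)F` stands on a different core; how that core differs from the core of compound 1 is not broken down here. In this assay compound 3 gives 50 nM, the lowest number of the three measured compounds. Compound 4 `CC(C)c1cc2[nH]ncc2cc1-c1ccccc1C(F)(F)F` has not yet been measured. It differs from compound 3 by methyl in place of hydrogen on a saturated chain carbon bound to an aromatic carbon and a saturated chain carbon. Going by the values given here, this is the same kind of change as the one from compound 1 to compound 2, but not the same: in compound 4 the carbon that gains the methyl is bound to an aromatic carbon and a saturated chain carbon, whereas in compound 2 it is bound to an aromatic carbon only. Among the compounds with values here, a smaller step is expected here, because a 13-fold lower number from compound 1 to compound 2 (1.13 log units; beyond the scatter) was measured on another core and at a differently described place, and only one such step is known. The expected step is a 1.7-fold lower number from compound 3 to compound 4 (0.22 log units; within the scatter). Compound 4 is therefore estimated to give 30 nM in this assay, most likely between 8 nM and 120 nM.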

Compound 4, half-maximal inhibitory concentration: 25400 nM
Estimate against measurement, compound 4: 850-fold (2.93 log units) below; the measured number lies above the stated range.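

In this assay the ethyl to isopropyl change gives a 510-fold higher number from compound 3 to compound 4 (2.71 log units; beyond the scatter) and so runs in the opposite direction to the earlier step, in which a methyl was also added. The effect of adding this methyl therefore does not carry over from one core to the other, in either size or direction: the same change on two cores in this assay, a 13-fold lower number (1.13 log units; beyond the scatter) from compound 1 to compound 2 and a 510-fold higher number (2.71 log units; beyond the scatter) from compound 3 to compound 4, 6800-fold (3.83 log units) apart, beyond the scatter of two such steps. This does not show why the two steps disagree: the cores differ, and so does the carbon that gains the methyl, so with one step of each kind, the two differences cannot be separated.

On these data alone, it remains open how the ethyl to isopropyl change would read on the core of compound 1, which would show whether the core or the carbon matters more. Also open, as far as these compounds go, is how a longer chain such as propyl, or a small ring such as cyclopropyl, would read at the same place on the core of compound 3 in this assay, and so whether the sharp rise is specific to isopropyl.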